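This account rests on a few compounds, and the source may have more. Where it says the series, first, only, none or still open, it means among the compounds named here.

Series in a functional assay on A2780 cells (Homo sapiens) for antiproliferative activity, read by MTT assay, with a stated time of 48 h; on this read-out higher numbers stand for weaker inhibition and lower numbers for stronger inhibition:
- compound 1 `COc1ccc(-c2cc3c(cn2)[nH]c(=O)n3-c2cc(OC)c(OC)c(OC)c2)cc1`: 930 nM
- compound 2 `COc1ccc(-c2cc3c(cn2)[nH]c(=O)n3-c2cc(OC)c(OC)c(OC)c2)cc1O`: 240 nM
- compound 3 `COc1ccc(-c2cc3c(cn2)[nH]c(=O)n3-c2cc(OC)c(OC)c(OC)c2)cn1`: not yet measured

Of the two measured compounds, compound 2 has the lower number, at 240 nM. The next step puts 6-methoxypyridin-3-yl in place of 3-hydroxy-4-methoxyphenyl on the shared core: 6-methoxypyridin-3-yl in place of 3-hydroxy-4-methoxyphenyl on an aromatic carbon. Going by the values given here, only one measured step bears on this: a 3.9-fold lower number from compound 1 to compound 2 (0.59 log units; beyond the scatter), a modest change that came with adding the hydroxy. Compound 3 has no hydroxy, as compound 1 has none, so much of that gain is expected to be lost. Among the compounds with values here, no measured step covers the ring nitrogen, which widens the range. A higher number in this assay is expected, of about the same size as the measured step, and the estimated change is a 3.3-fold higher number from compound 2 to compound 3 (0.52 log units; beyond the scatter). For compound 3 the estimated value is 800 nM, with an expected range of 250 nM to 2500 nM.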

Compound 3, half-maximal inhibitory concentration: 990 nM
Beside the measured number, compound 3's estimate is 1.2-fold (0.09 log units) below it; measured number inside the range.
By their numbers in this assay, from the lowest: compound 2; then compounds 1 and 3 (each within the scatter of the next).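

In this assay, 6-methoxypyridin-3-yl in place of 3-hydroxy-4-methoxyphenyl gives a 4.1-fold higher number from compound 2 to compound 3 (0.62 log units; beyond the scatter) and so does not hold the gain seen with the hydroxy. 6-Methoxypyridin-3-yl in place of 4-methoxyphenyl gives a 1.1-fold higher number from compound 1 to compound 3 (0.03 log units; within the scatter) and so shows that, at this position in this assay, the ring nitrogen brings no change beyond the scatter; of the three aryl groups, only 3-hydroxy-4-methoxyphenyl stands apart. No measurement at hand accounts for either step.

Open, on these data alone, is whether a hydroxy added to the 6-methoxypyridin-3-yl group would bring back the gain seen with the phenyl ring. Also open, as far as these compounds go, is whether an amine or a carboxylic acid in the place of that hydroxy would give a similar gain.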